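Hydroxymethyl for vinyl on the allyl-substituted compound

The source may hold more compounds than are shown below. What is called first, only, known or untested is meant among the compounds shown, and "the series" means these compounds.

Compound 1 `c1ccc(CSc2nc(-c3cc4ccccc4[nH]3)n[nH]2)cc1`: 4.53 ug/mL
Compound 2 `c1ccc(CSc2nc(-c3cc4ccccc4[nH]3)nn2Cc2ccccc2)cc1`: 10.8 ug/mL
Compound 3 `C=CCn1nc(-c2cc3ccccc3[nH]2)nc1SCc1ccccc1`: 15.5 ug/mL

All three values come from a functional assay on MCF7 cells (Homo sapiens) for antiproliferative activity, read by sulforhodamine B assay, with a stated time of 48 h; a higher number here means a weaker inhibitor, a lower number a stronger inhibitor. In this assay compound 3 gives 15.5 ug/mL. It stands within the scatter of compound 2, shown by a 1.4-fold higher number from compound 2 to compound 3 (0.16 log units; within the scatter), and clearly apart from compound 1, shown by a 3.4-fold higher number from compound 1 to compound 3 (0.53 log units; beyond the scatter).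

The next entry is compound 4 `OCCn1nc(-c2cc3ccccc3[nH]2)nc1SCc1ccccc1`, with hydroxymethyl in place of vinyl on a saturated chain carbon bound to an aromatic nitrogen. Among the measured compounds shown here, no measured step makes this exact exchange. The closest evidence at this place is a 1.4-fold higher number from compound 2 to compound 3 (0.16 log units; within the scatter), which stayed within the scatter. The modest steps of a 2.4-fold higher number from compound 1 to compound 2 (0.38 log units; beyond the scatter) and a 3.4-fold higher number from compound 1 to compound 3 (0.53 log units; beyond the scatter) both add a group on the aromatic nitrogen, and compound 4 also carries a group there. With only these compounds to go on, no step beyond the scatter is expected in this assay. The expected change is a 1.2-fold lower number from compound 3 to compound 4 (0.08 log units; within the scatter). Compound 4 is estimated at 13 ug/mL. The expected range for compound 4 runs from 5 ug/mL to 32 ug/mL.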

Compound 4, half-maximal inhibitory concentration: 14.6 ug/mL
For compound 4 the middle estimate is 1.1-fold (0.05 log units) below the measured one; low and high end bracket the measured number.
By their numbers in this assay, from the lowest: compound 1; then compounds 2, 4 and 3 (each within the scatter of the next).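

In this assay the change from allyl to 2-hydroxyethyl gives a 1.1-fold lower number from compound 3 to compound 4 (0.03 log units; within the scatter) and so brings a hydrogen-bond donor and acceptor onto a saturated chain carbon bound to an aromatic nitrogen without a step beyond the scatter. Among the compounds shown here, the comparison with the benzyl group gives a 1.4-fold higher number from compound 2 to compound 4 (0.13 log units; within the scatter) and likewise stays within the scatter, whereas replacing hydrogen on the aromatic nitrogen gives a 3.2-fold higher number from compound 1 to compound 4 (0.51 log units; beyond the scatter) and makes 2-hydroxyethyl the third group, after benzyl and allyl, to stand clearly apart from hydrogen, with no compound here going against this. Nothing available explains these results.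

As far as these compounds go, it remains open whether an amine or a carboxylic acid in place of the hydroxy group would also stay level with compound 3. A longer chain carrying the hydroxy group is equally untested among these compounds.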